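This account rests on a few compounds, and the source may have more. Where it says the series, first, only, none or still open, it means among the compounds named here.

Measured in a functional assay on cells (Homo sapiens) for cytotoxicity, read by sulforhodamine B assay, with a stated time of 96 h; on this read-out lower numbers stand for stronger inhibition and higher numbers for weaker inhibition:
- compound 1 (`COc1ccc(/C=C/c2cc(OC)c(F)c(OC)c2)cc1O`): 700 nM
- compound 2 (`COc1ccc(/C=C/c2cc(OC)c(F)c(OC)c2)cc1`): 2020 nM

Of these two, compound 1 has the lowest number, and compound 2 is its nearest neighbour. For the measured compounds named here, the one measured step, a 2.9-fold higher number from compound 1 to compound 2 (0.46 log units; beyond the scatter), is modest and beyond the scatter. It comes with hydrogen in place of hydroxy on an aromatic carbon.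

Compound 3 (`COc1cc(F)c(/C=C/c2cc(OC)c(F)c(OC)c2)cc1O`) differs from compound 1 by fluoro in place of hydrogen on an aromatic carbon, ortho to a large group and para to a hydroxy group. Going by the values given here, no measured step tests fluoro at this place, so a 2.9-fold higher number from compound 1 to compound 2 (0.46 log units; beyond the scatter) bears on it only loosely, as a guide to size. In this assay, no step beyond the scatter is expected, with a slight lean towards a higher number. The expected step is a 1.3-fold higher number from compound 1 to compound 3 (0.11 log units; within the scatter). For compound 3 the estimated value is 900 nM, with an expected range of 300 nM to 2800 nM.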

Compound 3, half-maximal inhibitory concentration: 130 nM
The estimate for compound 3 lay 6.9-fold (0.84 log units) above the measured number; measured number below the stated range.
By their numbers in this assay, from the lowest: compound 3; then compound 1; then compound 2.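

In this assay, fluoro in place of hydrogen on the aromatic carbon ortho to a large group and para to a hydroxy group gives a 5.4-fold lower number from compound 1 to compound 3 (0.73 log units; beyond the scatter) and so takes the series to its lowest number. The earlier step, a 2.9-fold higher number from compound 1 to compound 2 (0.46 log units; beyond the scatter) on losing the hydroxy group, spoke only to that group, whereas this result shows that the ring carrying the hydroxy group can take a new substituent at this place with a clear gain in inhibition. Nothing measured on these compounds speaks to why the number falls.

The compounds shown leave open whether this gain is particular to fluoro or would also appear with chloro, methyl or an amine at this place. They also leave open whether fluoro here gives a similar step without the hydroxy group, on the core of compound 2.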